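Sulfonyl substituent change in an adrenergic agonist series

The compounds below may be only part of what the source reports. "The series", "measured", "known", "first", "only" and "open" are said of these compounds alone.

Measured compounds:
compound 1, `O=S(=O)(Nc1cccc2c1CCCC2c1c[nH]cn1)C1CC1`, 5.25
compound 2, `CS(=O)(=O)Nc1cccc2c1CCCC2C1=NCCN1`, 6.19
compound 3, `CS(=O)(=O)Nc1ccc(F)c2c1CCCC2c1c[nH]cn1`, 5.31

All three were run in a functional assay on Urethra for agonist activity at Alpha-1A adrenergic receptor (Oryctolagus cuniculus); a lower number here means a less potent compound, a higher number a more potent compound, by a factor of ten per unit of this negative logarithm. Among them compound 1 carries the lowest of the three numbers; compound 3 sits within the scatter of it, while compound 2 lies beyond it, at a higher value.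

The unmeasured compound 4, `CC(C)S(=O)(=O)Nc1cccc2c1CCCC2c1c[nH]cn1`, differs from compound 1 in one place: isopropyl in place of cyclopropyl on a sulfonyl sulfur. For the measured compounds named here, no measured pair in this set shows a step of this kind, so nothing here fixes its size or sign. The expectation is a step from compound 1 to compound 4 of a number 0.05 log units higher from compound 1 to compound 4 (within the scatter) in this assay, that is, none beyond the scatter in either direction.

Compound 4 is therefore estimated at 5.3 in this assay, in a range from 4.8 to 5.8.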

Compound 4, negative logarithm of the half-maximal effective concentration: 5.17
Beside the measured number, compound 4's estimate is 0.13 log units above it; low and high end bracket the measured number.
By their numbers in this assay, from the lowest: compounds 4, 1 and 3 (each within the scatter of the next); then compound 2.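

In this assay, for the compounds shown here, isopropyl in place of cyclopropyl on a sulfonyl sulfur gives a number 0.08 log units lower from compound 1 to compound 4 (within the scatter), the first step that can be read at this position. The three-membered ring can thus be opened, with the same count of carbons, without a step beyond the scatter. Nothing available here bears on why the two groups read alike.

Still open, going by these compounds, is how a phenyl, a trifluoromethyl or a longer chain such as n-butyl on the sulfonyl sulfur would read. Also open, on these data alone, is how methyl there compares on the core of compound 1.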